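The source may report more compounds than this note shows. Statements on the series, on what has been measured and on what is new or still open speak of the compounds shown alone.

Of the compounds shown here, two built on a shared core have been measured so far. Compound 1 `O=C(NC1CCCCC1)Oc1cccc(-c2ccc(F)cc2)c1` gives 65 nM in an assay on cell membranes for binding affinity to Fatty-acid amide hydrolase 1 (Rattus norvegicus); on this read-out higher numbers stand for weaker inhibition and lower numbers for stronger inhibition. Compound 2 `O=C(NC1CCCCC1)Oc1cccc(-c2cccc(OC(=O)NC3CCCCC3)c2)c1` gives 361 nM in this assay, the higher of the two numbers; its nearest neighbour is compound 1, whose number lies lower by a margin beyond the usual scatter. Compound 3 `O=C(NC1CCCCC1)Oc1cccc(-c2cccc(-c3ccccc3)c2)c1` has not yet been measured. Compound 3 differs from compound 2 in one place: phenyl in place of (cyclohexylcarbamoyl)oxy on an aromatic carbon. For the measured compounds named here, no step between measured compounds that differ in one place is available; the size of this change cannot be read from a direct pair. Still, compound 1 with 65 nM shows that a lower number than that of compound 2 is reachable in this series. Compound 3 is expected to move in that direction, with an estimated 4.0-fold lower number from compound 2 to compound 3 (0.60 log units; beyond the scatter). The estimate for compound 3 is 90 nM, with a range from 25 nM to 320 nM.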

Compound 3, half-maximal inhibitory concentration: 565 nM
For compound 3 the middle estimate is 6.3-fold (0.80 log units) below the measured one, and the stated range ends below it.
By their numbers in this assay, from the lowest: compound 1; then compounds 2 and 3 (each within the scatter of the next).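

For the compounds shown here, the first direct pair at this position gives a 1.6-fold higher number from compound 2 to compound 3 (0.19 log units; within the scatter) in this assay, so the two compounds cannot be told apart on this read-out. The change is a large one on paper: (cyclohexylcarbamoyl)oxy, with 10 heavy atoms, a non-aromatic ring, a hydrogen-bond donor and hydrogen-bond acceptors, gives way to phenyl, with 6 heavy atoms and no donor or acceptor, yet in this pair that exchange on an aromatic carbon brings no readable difference. Nothing measured here explains why these two groups give such similar numbers.

On these data alone, what an amine or a carboxylic acid on this aromatic carbon would give remains open. As far as these compounds go, it is also open whether a longer carbon chain in this place would give a number in the same range.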